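This account rests on a few compounds, and the source may have more. Where it says the series, first, only, none or still open, it means among the compounds named here.

The measured compounds in this set are:

compound 1, `O=C(O)CCc1ccc(NCc2ccccc2)cc1`, with 89%
compound 2, `O=C(O)CCc1ccc(OCc2cccc(Br)c2)cc1`, with 99%
compound 3, `O=C(O)CCc1ccc(NCc2cccc(Br)c2)cc1`, with 110%

In a functional assay on 1321-N1 cells for agonist activity at Free fatty acid receptor 1 (Homo sapiens), read by calcium flux (on this read-out lower numbers stand for smaller maximal responses and higher numbers for larger maximal responses), compound 3 gives the highest number of the three. Compound 2 stands nearest to it, and its number is lower by more than the scatter; compound 1 stands furthest, lower still. For the measured compounds named here, the one step that reaches compound 3 is a number 21 percentage points higher from compound 1 to compound 3 (beyond the scatter), so the bromo group on the ring of the benzyl amine is tied to a modest rise in the maximal response.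

Compound 4, `O=C(O)CCc1ccc(NCc2cccc(C(F)(F)F)c2)cc1`, is the next compound. It differs from compound 3 in one place: trifluoromethyl in place of bromo on an aromatic carbon.

Going by the values given here, no measured step exchanges bromo for trifluoromethyl, so the only guidance is that the position carrying the bromo in compound 3 is one where a change was felt, as the step of a number 21 percentage points higher from compound 1 to compound 3 (beyond the scatter) shows. Since trifluoromethyl is again a substituent at that same place, no further rise beyond the scatter is expected, and a drop back towards compound 1 is not expected either.

Compound 4 is therefore expected to give 105%, between 90% and 120%. The expected step, a number 5 percentage points lower from compound 3 to compound 4 (within the scatter), lies within the scatter.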

Compound 4, largest response reached (reported as efficacy), in percent of the reference or control that the assay uses: 102%
Compound 4: the middle estimate sits 3 percentage points above what was measured, and the stated range covers the measured number.
By their numbers in this assay, from the lowest: compounds 1, 2, 4 and 3 (each within the scatter of the next, the first and the last beyond it).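

In this assay, trifluoromethyl in place of bromo gives a number 8 percentage points lower from compound 3 to compound 4 (within the scatter), so this aromatic carbon accepts either group, with one heavy atom leaving and four entering, without a change in maximal response that stands clear of the scatter. Set against hydrogen at the same place, trifluoromethyl gives a number 13 percentage points higher from compound 1 to compound 4 (beyond the scatter), so the rise seen earlier with bromo is not tied to bromo alone: two different substituents here both stand beyond the scatter above compound 1. Nothing available explains why the two groups give maximal responses that cannot be told apart.

On these data alone, whether this holds for other kinds of substituent, such as a methoxy group, a nitrile or a single fluorine, remains open, as does whether the same groups would act alike on another carbon of that ring. As far as these compounds go, it is also open whether trifluoromethyl in place of bromo would leave the response of compound 2 unchanged, and these numbers speak only of maximal response, so they say nothing about the concentrations needed to reach it.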